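Changing the side ring of compound 2

The compounds below may be only part of what the source reports. "The series", "measured", "known", "first", "only" and "open" are said of these compounds alone.

Measured in a physicochemical assay for solubility, read by HPLC, in phosphate buffer, at pH 6.5; on this read-out lower numbers stand for lower solubility and higher numbers for higher solubility:
Compound 1 `COC(=O)C1=C(CN2CCNCC2)NC(c2nccs2)=NC1(C)c1ccc(F)cc1` gives 250 ug/mL
Compound 2 `COC(=O)C1=C(CN2CCOCC2=O)NC(c2nccs2)=NC1(C)c1ccc(F)cc1` gives 440 ug/mL

Within the data shown here, only two numbers exist so far, and compound 2 lies within the usual scatter of compound 1, so the pair cannot be ranked. Compound 3 `COC(=O)C1=C(CN2CCC(O)CC2)NC(c2nccs2)=NC1(C)c1ccc(F)cc1` has not yet been measured. It carries 4-hydroxypiperidin-1-yl in place of 3-oxomorpholin-4-yl on a saturated chain carbon bound to a double-bonded ring carbon. Among the measured compounds shown here, one measured step bears on this change, as it concerns the same place: a 1.8-fold higher number from compound 1 to compound 2 (0.25 log units; within the scatter). That step stays within the scatter, so this single comparison gives no reason to expect a real shift in this assay. The expected change is small, and no direction can be claimed with confidence: a 1.4-fold lower number from compound 2 to compound 3 (0.14 log units; within the scatter). Compound 3 is estimated at 320 ug/mL, with an expected range of 140 ug/mL to 700 ug/mL.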

Compound 3, solubility: 593 ug/mL
Compound 3: the middle estimate sits 1.9-fold (0.27 log units) below what was measured; measured number inside the range.
By their numbers in this assay, from the lowest: compounds 1, 2 and 3 (each within the scatter of the next, the first and the last beyond it).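

In this assay, the swap at this place gives a 1.3-fold higher number from compound 2 to compound 3 (0.13 log units; within the scatter), so 3-oxomorpholin-4-yl and 4-hydroxypiperidin-1-yl cannot be told apart, even though only the entering ring has a hydrogen-bond donor. Among these compounds, the comparison with piperazin-1-yl gives a 2.4-fold higher number from compound 1 to compound 3 (0.38 log units; beyond the scatter), the only step in this small set that passes the scatter, though modestly, which shows that the choice of side ring on this saturated chain carbon can move the read-out. No supporting measurement is available to explain this difference.

Still open, as far as these compounds go, is how a simple dimethylamino group or a carboxylic acid would read at this same place in this assay. Also open, from the compounds shown here alone, is whether a longer chain carrying 4-hydroxypiperidin-1-yl would keep the number seen for compound 3.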